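The source may hold more compounds than are shown below. What is called first, only, known or untested is meant among the compounds shown, and "the series" means these compounds.

Working notes on the series. Of the compounds shown here, three have been measured in a functional assay on HEK293 cells for negative allosteric modulation of metabotropic glutamate receptor 5 (Homo sapiens), read by HTRF and inositol phosphate accumulation; on this read-out lower numbers stand for stronger inhibition and higher numbers for weaker inhibition. Compound 1 `CCC[C@@H](NC(=O)c1nccs1)c1cnc(Nc2ccc(C)nc2)c(Cl)c1` gives 8.2 nM in this assay; compound 2 `Cc1ccc(Nc2ncc([C@H](NC(=O)c3nccs3)C(C)(C)C)cc2Cl)cn1` gives 30.9 nM; compound 3 `Cc1ccc(Nc2ncc([C@H](NC(=O)c3nccs3)C3CCCC3)cc2Cl)cn1` gives 16.6 nM. Compound 3 thus has the second highest of the three numbers: there was a 2.0-fold higher number from compound 1 to compound 3 (0.31 log units; beyond the scatter), while a 1.9-fold lower number from compound 2 to compound 3 (0.27 log units; within the scatter) stays inside the scatter. Compound 4 `C=CC[C@@H](NC(=O)c1nccs1)c1cnc(Nc2ccc(C)nc2)c(Cl)c1` brings (allyl in place of cyclopentyl on a saturated chain carbon bound to an amide-type nitrogen and an aromatic carbon). The step that bears most on it is a 2.0-fold higher number from compound 1 to compound 3 (0.31 log units; beyond the scatter), since allyl, like propyl, is an open chain without a ring; the step of a 3.8-fold higher number from compound 1 to compound 2 (0.58 log units; beyond the scatter) also points to the ring-free chain giving the lower number. A modest step back toward compound 1 is therefore expected, namely a 1.7-fold lower number from compound 3 to compound 4 (0.22 log units; within the scatter). Compound 4 is estimated at 10 nM, in the range 5 nM to 20 nM.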

Compound 4, half-maximal inhibitory concentration: 2.4 nM
For compound 4 the middle estimate is 4.2-fold (0.62 log units) above the measured one; the whole stated range lies above it.
By their numbers in this assay, from the lowest: compound 4; then compound 1; then compounds 3 and 2 (each within the scatter of the next).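

In this assay the double bond itself counts at this position: vinyl in place of ethyl gives a 3.4-fold lower number from compound 1 to compound 4 (0.53 log units; beyond the scatter) and leaves compound 4 with the lowest number of the four. The steps from the branched and ring groups are wider, with a 6.9-fold lower number from compound 3 to compound 4 (0.84 log units; beyond the scatter) for allyl in place of cyclopentyl and a 13-fold lower number from compound 2 to compound 4 (1.11 log units; beyond the scatter) for allyl in place of tert-butyl. Nothing at hand gives a reason for these steps.

Still open, from the compounds shown here alone, is whether a propargyl group, with a triple bond, matches allyl on this carbon. Also open, going by these compounds, is whether a longer chain ending in a double bond, such as butenyl, keeps the low number.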